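The source may report more compounds than this note shows. Statements on the series, on what has been measured and on what is new or still open speak of the compounds shown alone.

Working notes on the series. Compound 1 `COc1cc2ncnc(Nc3ccc(Br)cc3F)c2cc1OCCCN1CCNCCNCCNCC1` is the reference point. Within the data shown here, in a functional assay on A-431 cells (Homo sapiens) for antiproliferative activity, read by MTT assay, with a stated time of 72 h (on this read-out higher numbers stand for weaker inhibition and lower numbers for stronger inhibition), compound 1 gives 1840 nM, the second highest of the three numbers so far. Compound 2 `COc1cc2ncnc(Nc3cccc(Cl)c3)c2cc1OCCCN1CCNCCNCCNCC1` gives 1420 nM and compound 3 `COc1cccc(Nc2ncnc3cc(OC)c(OCCCN4CCNCCNCCNCC4)cc23)c1` gives 3210 nM. The steps among these three are small: a 1.3-fold lower number from compound 1 to compound 2 (0.11 log units; within the scatter) and a 1.7-fold higher number from compound 1 to compound 3 (0.24 log units; within the scatter) both stay within the scatter, and only a 2.3-fold higher number from compound 2 to compound 3 (0.35 log units; beyond the scatter) passes beyond it, and then only modestly.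

Compound 4 `CCc1cc(Br)ccc1Nc1ncnc2cc(OC)c(OCCCN3CCNCCNCCNCC3)cc12` has not yet been measured. It differs from compound 1 by ethyl in place of fluoro on an aromatic carbon. Among the measured compounds shown here, no measured step covers this kind of exchange on the aryl ring; the two steps that start from compound 1 replace the whole 4-bromo-2-fluorophenyl group and move the number little, and the one modest step concerns a different group. The expectation for compound 4 is therefore a step of no clear direction and of a size inside the usual scatter. Compound 4 is expected to give about 1800 nM, with a range from 800 nM to 4000 nM, which means an expected step of a 1.0-fold lower number from compound 1 to compound 4 (0.01 log units; within the scatter).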

Compound 4, half-maximal inhibitory concentration: 5650 nM
For compound 4 the middle estimate is 3.1-fold (0.50 log units) below the measured one; the whole stated range lies below it.
By their numbers in this assay, from the lowest: compounds 2, 1, 3 and 4 (each within the scatter of the next, the first and the last beyond it).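

Ethyl in place of fluoro, on an aromatic carbon ortho to a large group, gives a 3.1-fold higher number from compound 1 to compound 4 (0.49 log units; beyond the scatter) in this assay. Among these compounds, this is the first step from compound 1 to pass beyond the scatter, and it comes from one substituent, whereas the two exchanges of the whole 4-bromo-2-fluorophenyl group stayed within it. The 4-bromo-2-ethylphenyl group also separates from the 3-chlorophenyl group in a 4.0-fold higher number from compound 2 to compound 4 (0.60 log units; beyond the scatter) but not from the 3-methoxyphenyl group in a 1.8-fold higher number from compound 3 to compound 4 (0.25 log units; within the scatter), and no data shown bear on what lies behind the step.

As far as these compounds go, with a single exchange at this position, it stays open whether methyl, isopropyl or an amine on the same aromatic carbon would fall nearer compound 1 or compound 4. From the compounds shown here alone, it is also open whether the step would hold with a group other than bromo on the ring.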